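From Compound 1 to Compound 4: an Amide Swap

The source may hold more compounds than are shown below. What is called first, only, known or untested is meant among the compounds shown, and "the series" means these compounds.

Compound 1 `O=C(CCC(=O)OCCCCCCSc1ccc([N+](=O)[O-])c2nonc12)Nc1ccccc1Cl` was tested in an ADME assay on HUVEC cells (Homo sapiens) for cytotoxicity, read by MTT assay, with a stated time of 72 h (on this read-out higher numbers stand for weaker inhibition and lower numbers for stronger inhibition), where compound 1 gives 2950 nM. Among the three measured compounds this is the highest number, yet no neighbour stands beyond the scatter. Compound 2 `O=C(CCC(=O)OCCCCCCSc1ccc([N+](=O)[O-])c2nonc12)Nc1ccc(F)cc1` gives 1740 nM in this assay, a step of a 1.7-fold lower number from compound 1 to compound 2 (0.23 log units; within the scatter). Compound 3 `CN(C)CCNC(=O)CCC(=O)OCCCCCCSc1ccc([N+](=O)[O-])c2nonc12` gives 2160 nM in this assay, a step of a 1.4-fold lower number from compound 1 to compound 3 (0.14 log units; within the scatter). Between the two of them the step is a 1.2-fold higher number from compound 2 to compound 3 (0.09 log units; within the scatter).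

Compound 4 `O=C(CCC(=O)N1CCOCC1)OCCCCCCSc1ccc([N+](=O)[O-])c2nonc12` differs from compound 1 in one place: morpholin-4-yl in place of (2-chlorophenyl)amino on a carbonyl carbon. Within the data shown here, the steps that bear on this are the two exchanges on the amide-type nitrogen, a 1.7-fold lower number from compound 1 to compound 2 (0.23 log units; within the scatter) and a 1.4-fold lower number from compound 1 to compound 3 (0.14 log units; within the scatter), both within the scatter; compound 3 is the closer guide, since its 2-(dimethylamino)ethyl also left the 2-chlorophenyl behind. Among the measured compounds shown here, no measured compound removes the hydrogen-bond donor, so that part of the change is untested. Compound 4 is therefore expected to give 2400 nM in this assay, within a range of 1100 nM to 5200 nM. The expected step, a 1.2-fold lower number from compound 1 to compound 4 (0.09 log units; within the scatter), is estimated to stay within the scatter.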

Compound 4, half-maximal inhibitory concentration: 5340 nM
Beside the measured number, compound 4's estimate is 2.2-fold (0.35 log units) below it; measured number outside the range, above it.
By their numbers in this assay, from the lowest: compounds 2, 3, 1 and 4 (each within the scatter of the next, the first and the last beyond it).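

Morpholin-4-yl is the first group on this carbonyl carbon to move the number beyond the scatter in this assay, with a 2.5-fold higher number from compound 3 to compound 4 (0.39 log units; beyond the scatter) and a 3.1-fold higher number from compound 2 to compound 4 (0.49 log units; beyond the scatter), whereas compounds 1, 2 and 3, which all keep the amide hydrogen, stand within the scatter of one another. Compound 1 goes against a clean separation, since a 1.8-fold higher number from compound 1 to compound 4 (0.26 log units; within the scatter) remains within the scatter, so the change is clear only against two of the three amides. No evidence is available that explains this shift.

The compounds shown leave apart the loss of the amide hydrogen and the arrival of the morpholine ring itself. A (2-(morpholin-4-yl)ethyl)amino group would keep that hydrogen along with the ring, while a piperidin-1-yl or dimethylamino group on the same carbonyl carbon would lack the hydrogen and the ring oxygen alike.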